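The source may report more compounds than this note shows. Statements on the series, on what has been measured and on what is new or still open speak of the compounds shown alone.

Three compounds have been measured in a functional assay on CHO cells for antagonist activity at metabotropic glutamate receptor 5 (Homo sapiens), read by calcium flux; a lower number here means a stronger inhibitor, a higher number a weaker inhibitor:
compound 1 `Cc1c(C(C)OC(=O)Nc2ccccc2)oc2ncnn12` gives 63.1 nM;
compound 2 `Cc1c(C(C)OC(=O)Nc2ccccc2Cl)oc2ncnn12` gives 501 nM;
compound 3 `Cc1c(C(C)OC(=O)Nc2cccc(Cl)c2)oc2ncnn12` gives 39.8 nM.

Compound 3 has the lowest number of the three in this assay. Compound 1 stands nearest to it (a 1.6-fold lower number from compound 1 to compound 3 (0.20 log units; within the scatter)), compound 2 furthest (a 13-fold lower number from compound 2 to compound 3 (1.10 log units; beyond the scatter)). Compound 4 `Cc1c(C(C)OC(=O)Nc2ccc(Cl)c(Cl)c2)oc2ncnn12` differs from compound 3 by chloro in place of hydrogen on an aromatic carbon. Among the compounds with values here, two measured steps bear on this change, each a chloro entering in place of hydrogen, though at other positions on the ring: a 1.6-fold lower number from compound 1 to compound 3 (0.20 log units; within the scatter) and a 7.9-fold higher number from compound 1 to compound 2 (0.90 log units; beyond the scatter). Neither lowered the number beyond the scatter, and one raised it clearly. Compound 4 is therefore expected to give about 50 nM in this assay, within 15 nM to 160 nM, an expected step of a 1.3-fold higher number from compound 3 to compound 4 (0.10 log units; within the scatter).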

Compound 4, half-maximal inhibitory concentration: 5010 nM
Estimate against measurement, compound 4: 100-fold (2.00 log units) below; measured number above the stated range.
By their numbers in this assay, from the lowest: compounds 3 and 1 (each within the scatter of the next); then compound 2; then compound 4.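

A chloro entering ortho to a chloro group and para to a large group gives a 130-fold higher number from compound 3 to compound 4 (2.10 log units; beyond the scatter), so this position tolerates the change far less than the one that gave a 1.6-fold lower number from compound 1 to compound 3 (0.20 log units; within the scatter). The same replacement of hydrogen by chloro therefore has no single effect across the ring, and here it raises the number well beyond the other clear rise: the same change on two cores in this assay, a 7.9-fold higher number (0.90 log units; beyond the scatter) from compound 1 to compound 2 and a 130-fold higher number (2.10 log units; beyond the scatter) from compound 3 to compound 4, 16-fold (1.20 log units) apart, beyond the scatter of two such steps

Going by these compounds, it remains open whether a chloro at this position would raise the number as far without the other chloro present. On these data alone, whether a fluoro or a methoxy there would behave the same also remains open.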